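This account rests on a few compounds, and the source may have more. Where it says the series, first, only, none or still open, it means among the compounds named here.

Working notes on the series. Compound 1 `CNC(=O)c1cc(Oc2ccc3nc(NC(=O)Nc4ccc(Br)cc4)sc3c2)ccn1` is the reference point. For the measured compounds named here, in a functional assay on HCT-116 cells (Homo sapiens) for inhibition, read by MTT assay, with a stated time of 2 days, tested at 100 uM (a lower number here means less inhibition of growth, a higher number more inhibition of growth at the concentration tested), compound 1 gives 80%, the highest of the two numbers measured so far, and compound 2 `CNC(=O)c1cc(Oc2ccc3nc(NC(=O)c4ccc(Cl)cc4Cl)sc3c2)ccn1` gives 64.4% in this assay. Going by the values given here, the single measured step, a number 15.6 percentage points lower from compound 1 to compound 2 (beyond the scatter), concerns the group on the carbonyl carbon, not the aromatic carbon that is altered in the next compound. Compound 3 `CNC(=O)c1cc(Oc2ccc3nc(NC(=O)Nc4ccc(N5CCN(C)CC5)cc4)sc3c2)ccn1` differs from compound 1 as follows: 4-methylpiperazin-1-yl in place of bromo on an aromatic carbon. Among the compounds with values here, no measured step touches this position or this group, so the step from compound 1 to compound 2 offers only a rough sense of scale: one change elsewhere in the molecule moved this assay by a modest amount. With compound 1 already near the top of the read-out, a large rise is unlikely, and the expected direction is a small move downward, a number 8 percentage points lower from compound 1 to compound 3 (within the scatter), which may well stay within the scatter. Compound 3 is therefore estimated at 72% in this assay, with a range from 45% to 92%.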

Compound 3, percent growth inhibition at one concentration: 95%
Compound 3: middle estimate off by 23 percentage points, on the low side; the whole stated range lies below it.
By their numbers in this assay, from the lowest: compound 2; then compound 1; then compound 3.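

For the compounds shown here, the para position on the aromatic ring of carbon only responds in this assay, which the step from compound 1 to compound 2 at the carbonyl carbon could not show: 4-methylpiperazin-1-yl in place of bromo gives a number 15 percentage points higher from compound 1 to compound 3 (beyond the scatter) and is the first change at this position. The position therefore accepts far more than a single bromine atom, since a group of 7 heavy atoms with a six-membered non-aromatic ring and 2 hydrogen-bond acceptors carries no loss of growth inhibition in this comparison. Nothing available on these compounds accounts for the rise, so the step stands as an observation without an explanation.

The compounds shown leave open whether the rise depends on the piperazine ring itself or would also appear with a morpholin-4-yl ring, a simple dimethylamino group or a carboxylic acid at the same place. They also leave open whether the same replacement would give a comparable step on a compound carrying the 2,4-dichlorophenyl group on the carbonyl carbon, and how the result at a single concentration would translate across a range of concentrations.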